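The compounds below may be only part of what the source reports. "The series", "measured", "known", "first", "only" and "open" are said of these compounds alone.

In a functional assay on DU-145 cells (Homo sapiens) for inhibition, read by trypan blue exclusion, with a stated time of 96 h (on this read-out lower numbers stand for stronger inhibition of growth and higher numbers for weaker inhibition of growth), compound 1 (`CSc1ccc(/C=C(\C(=O)c2ccc(Cl)cc2)S(=O)(=O)Cc2ccc(C)cc2)cc1`) gives 10000 nM. Compound 2 (`Cc1ccc(C)c(/C=C(\C(=O)c2ccc(Cl)cc2)S(=O)(=O)Cc2ccc(Cl)cc2)c1`) gives 10000 nM, so it stands level with compound 1 at the digits reported, and neither value can be placed ahead of the other.

Within the data shown here, the next compound to be tested is compound 3 (`CSc1ccc(/C=C(\C(=O)c2ccc(Cl)cc2)S(=O)(=O)Cc2ccc(Cl)cc2)cc1`), which has no measurement yet. It differs from compound 2 in one place, with 4-(methylsulfanyl)phenyl in place of 2,5-dimethylphenyl on a double-bonded chain carbon bound to a double-bonded chain carbon. Among the measured compounds shown here, no pair of measured compounds here shows this change on its own, so the data offer no direct guide to its size.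

The entering group does appear in compound 1, which gives 10000 nM. A change within the scatter of this assay is therefore the expected outcome, although a modest shift towards stronger inhibition of growth remains possible. The expected step is a 1.3-fold lower number from compound 2 to compound 3 (0.10 log units; within the scatter). The estimate for compound 3 is 8000 nM, with an expected range of 2000 nM to 20000 nM.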

Compound 3, concentration for 50% growth inhibition: 10000 nM
Compound 3: the middle estimate sits 1.3-fold (0.10 log units) below what was measured; the range from low to high includes it.
By their numbers in this assay, from the lowest: compounds 1, 2 and 3 (each within the scatter of the next).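

In this assay, the swap of 2,5-dimethylphenyl for 4-(methylsulfanyl)phenyl on a double-bonded chain carbon bound to a double-bonded chain carbon can now be read directly, and the result is no change at the digits printed from compound 2 to compound 3 (within the scatter). Compound 3 also provides a second comparison at a different place, chloro in place of methyl on an aromatic carbon, and this reads no change at the digits printed from compound 1 to compound 3 (within the scatter). Neither single change separates the compounds it links, and nothing else available here offers an explanation for these two readings.

What the compounds shown leave open is whether a quite different group at the same chain carbon, such as an amine-bearing phenyl or a carboxylic acid, would move the number away from this shared level. With all three compounds level, they also cannot show which parts of the shared core matter for growth inhibition, or whether a longer chain in place of the chloro or methyl on the aromatic carbon would change the result.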